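The compounds below may be only part of what the source reports. "The series", "measured", "known", "first", "only" and "open" are said of these compounds alone.

Measured compounds:

Compound 1 `O=C1C(N2CCCC2)=CC(=O)c2c1nc1n2[C@H]2OC[C@@H](O)[C@H]2OC1`, which in a functional assay on HeLa cells (Homo sapiens) for inhibition, read by sulforhodamine B assay (on this read-out lower numbers stand for stronger inhibition and higher numbers for weaker inhibition), reaches only the assay limit > 16000 nM.
Compound 2 `O=C1C=C(Nc2cccc(Cl)c2)C(=O)c2c1nc1n2[C@H]2OC[C@@H](O)[C@H]2OC1`, which in this assay gives 6040 nM.
Compound 3 `O=C1C(Nc2cccc(Cl)c2)=CC(=O)c2c1nc1n2[C@H]2OC[C@@H](O)[C@H]2OC1`, which in this assay gives 7970 nM.

The value for compound 1 is a limit of the assay, not a number. Compounds 2 and 3 are built from the same atoms joined differently; the difference between their two cores is not broken down here, and their two values sit within the usual scatter of each other, so neither can be called stronger.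

Compound 3 turns into compound 1 by a single change, (pyrrolidin-1-yl in place of (3-chlorophenyl)amino on a double-bonded ring carbon), and that change made a step of an at least 2.0-fold higher number from compound 3 to compound 1 (0.30 log units; that floor lies within the scatter). The same change, (pyrrolidin-1-yl in place of (3-chlorophenyl)amino on a double-bonded ring carbon), turns compound 2 into the as yet unmeasured compound 4 `O=C1C=C(N2CCCC2)C(=O)c2c1nc1n2[C@H]2OC[C@@H](O)[C@H]2OC1`.

For compound 4 in this assay a step of a 2.6-fold higher number from compound 2 to compound 4 (0.42 log units; beyond the scatter) is expected, set beside the measured one. This expectation rests on compound 3, whose step an at least 2.0-fold higher number from compound 3 to compound 1 (0.30 log units; that floor lies within the scatter) ends at the assay limit (the limit of > 16000 nM in this assay, at which 1 of the 3 values shown sits). The estimate for compound 4 in this assay is therefore 16000 nM, expected to fall between 7000 nM and 40000 nM, with a fair chance that only a limit is reported.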

Compound 4, half-maximal inhibitory concentration: > 16000 nM
Compound 4 gave a limit, no number (the forecaster's own chance of this, stated with the estimate: 55%); the middle value sits exactly at the limit.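

In this assay, replacing (3-chlorophenyl)amino with pyrrolidin-1-yl on the double-bonded ring carbon gives a step of an at least 2.6-fold higher number from compound 2 to compound 4 (0.42 log units; beyond the scatter), so on the core of compound 2 the change weakens inhibition beyond the usual scatter. Going by these compounds, compound 4 reaches only a limit of the assay, > 16000 nM, and not a number, so the full size of this step stays unknown. On the core of compound 3 the floor of the same step lies within the scatter, so this pair does not show that the change carries over from one core to the other with the same size, or with a different one: the same change on two cores in this assay, an at least 2.0-fold higher number (0.30 log units; that floor lies within the scatter) from compound 3 to compound 1 and an at least 2.6-fold higher number (0.42 log units; beyond the scatter) from compound 2 to compound 4; the limit leaves it open whether they differ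

The aromatic ring and the hydrogen-bond donor leave together with (3-chlorophenyl)amino, so the compounds shown cannot tell which of them matters. On these data alone, it also stays open how a plain anilino group, a morpholine or an open-chain amine such as diethylamino would fare on either core.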